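A few compounds are considered here, and "the series" means these few. Any claim that something is new, unique, unknown or untested is made for them only; others in the source may bear on it.

Of the compounds shown here, three have so far been measured in an assay on Ltk cells with metabotropic glutamate receptor 5 (Homo sapiens) as the target, read by fluorescence and calcium flux; on this read-out lower numbers stand for stronger inhibition and higher numbers for weaker inhibition. Compound 1 `CCCOc1cccnc1Nc1cccc(C)n1` gives 1600 nM, compound 2 `CCOc1c(C)ccnc1Nc1cccc(C)n1` gives 2700 nM, and compound 3 `CCOc1cc(C#N)cnc1Nc1cccc(C)n1` gives 46 nM. Compound 3 therefore stands lowest of the three, and its gaps to compound 1 and to compound 2 both lie beyond the usual scatter, so it is the most potent of this small set. Compound 4 `CCOc1cc(-c2cccc(F)c2)cnc1Nc1cccc(C)n1` has not yet been measured; it differs from compound 3 in one place: 3-fluorophenyl in place of cyano on an aromatic carbon. For the measured compounds named here, no two measured compounds differ in a single place, so no measured single-site step is available to guide the expectation. Because compound 3 gives 46 nM while carrying the cyano group, removing that group is expected to weaken inhibition. The step from compound 3 to compound 4 is expected to be a 6.5-fold higher number from compound 3 to compound 4 (0.81 log units; beyond the scatter). Compound 4 is estimated at 300 nM, with a range from 50 nM to 2000 nM.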

Compound 4, half-maximal inhibitory concentration: 126 nM
Compound 4: the middle estimate sits 2.4-fold (0.38 log units) above what was measured; measured number inside the range.
By their numbers in this assay, from the lowest: compound 3; then compound 4; then compounds 1 and 2 (each within the scatter of the next).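

Swapping cyano for 3-fluorophenyl on this aromatic carbon gives a 2.7-fold higher number from compound 3 to compound 4 (0.44 log units; beyond the scatter) in this assay and so costs only modestly, even though the entering group is much larger and brings a whole aromatic ring. That group counts no hydrogen-bond acceptor, so inhibition at this position does not depend on having the acceptor that cyano carries. Nothing available explains why the number rises. Going by these compounds, whether the fluorine contributes remains open, as does how a plain phenyl, an amine or a carboxylic acid would fare at this position.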